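The source may report more compounds than this note shows. Statements on the series, on what has been measured and on what is new or still open speak of the compounds shown alone.

In a functional assay on G-361 cells (Homo sapiens) for inhibition, with a stated time of 72 h (a lower number here means a stronger inhibitor, a higher number a weaker inhibitor), compound 1 `NC1CCC(Nc2nc(NCc3ccc(-c4ccsc4)cc3)c3ncn(C4CCCC4)c3n2)CC1` gives 570 nM, compound 2 `NC1CCC(Nc2nc(NCc3ccc(-c4cccc(F)c4)nc3)c3ncn(C4CCCC4)c3n2)CC1` gives 49 nM and compound 3 `NC1CCC(Nc2nc(NCc3ccc(-c4ccco4)nc3)c3ncn(C4CCCC4)c3n2)CC1` gives 97 nM. Compound 3 therefore cannot be told apart from compound 2, and it lies clearly lower than compound 1. Compound 4 `OC1CCC(Nc2nc(NCc3ccc(-c4ccco4)nc3)c3ncn(C4CCCC4)c3n2)CC1` differs from compound 3 in one group: hydroxy in place of amino on a saturated ring carbon. Among the measured compounds shown here, no measured step touches this group. The two measured steps, a 5.9-fold lower number from compound 1 to compound 3 (0.77 log units; beyond the scatter) and a 2.0-fold higher number from compound 2 to compound 3 (0.30 log units; within the scatter), lie elsewhere in the molecule and show only how far single changes have moved the number in this small set. A modest rise is expected, with little direct support. The estimated change is a 2.3-fold higher number from compound 3 to compound 4 (0.36 log units; beyond the scatter). For compound 4 the expected value is 220 nM, within an estimated range of 80 nM to 600 nM.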

Compound 4, half-maximal inhibitory concentration: 443 nM
Estimate against measurement, compound 4: 2.0-fold (0.30 log units) below; measured number inside the range.
By their numbers in this assay, from the lowest: compounds 2 and 3 (each within the scatter of the next); then compounds 4 and 1 (each within the scatter of the next).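

Among the compounds shown here, the earlier compounds all carry 4-aminocyclohexyl, so this is the first look at that end of the molecule: in this assay, changing to 4-hydroxycyclohexyl gives a 4.6-fold higher number from compound 3 to compound 4 (0.66 log units; beyond the scatter) on the same furan-bearing compound. The change is a single atom, and the two groups have the same counts of hydrogen-bond donors and acceptors, yet the number still moves beyond the scatter. Nothing measured here explains this step.

Still open, as far as these compounds go, is how a methylamino or methoxy group on this ring carbon would compare. From the compounds shown here alone, it is also open whether the same swap would give a similar step on compound 2, which carries 3-fluorophenyl instead of furan-2-yl.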